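The source may report more compounds than this note shows. Statements on the series, on what has been measured and on what is new or still open speak of the compounds shown alone.

Measured so far in a physicochemical assay for lipophilicity, at pH 7.4 (a lower number here means a more polar compound, a higher number a more lipophilic compound), for this series:
- compound 1 `COCc1cccc2c1CC[C@H]2c1ncc[nH]1` gives 1.8
- compound 2 `CCOCc1cccc2c1CCC2c1ncc[nH]1` gives 2.1

Compound 1 and compound 2 lie within the usual scatter of repeated measurements of each other, so these two values set no order between them. Among the compounds with values here, they are also the only numbers available in this assay so far.

Compound 3 `COCc1c(F)ccc2c1CC[C@H]2c1ncc[nH]1` has not yet been measured. It differs from compound 1 by a single change: fluoro in place of hydrogen on an aromatic carbon with fluoro in place of hydrogen on an aromatic carbon. The fluoro stands ortho to a methoxymethyl group, meta to a fused ring and para to a fused ring.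

Within the data shown here, no measured pair shows this change alone, so the expectation has no measured step behind it. A small upward step is expected, one that may not clear the scatter. The estimated step is a number 0.20 log units higher from compound 1 to compound 3 (within the scatter) in this assay for now. Compound 3 is expected at 2 with an estimated range from 1.7 to 2.3 in this measurement.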

Compound 3, distribution coefficient: 2
Compound 3: the middle estimate sits on the measured number at the digits printed; the measured number falls inside the stated range.
By their numbers in this assay, from the lowest: compounds 1, 3 and 2 (each within the scatter of the next).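

In this assay, within the data shown here, the replacement of hydrogen by fluoro gives a number 0.20 log units higher from compound 1 to compound 3 (within the scatter) and provides the first step between compounds that differ in one place. Among these compounds, the fluoro stands ortho to a methoxymethyl group, meta to a fused ring and para to a fused ring, and at this position the single change leaves the two compounds within the scatter of each other, so it sets no order between them. No independent evidence bears on the size of this step or offers a reason for it.

This one pair leaves open whether fluoro on the other aromatic carbons of the same ring would also stay within the scatter, and whether a different group on this carbon, such as chloro, trifluoromethyl, an amine or a carboxylic acid, would move the number beyond it. Also open, going by these compounds, is whether the same change would give a step of similar size on a compound with a longer chain in place of the methoxymethyl group, since a single pair cannot show how the step depends on its surroundings.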